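Methylcarbamoyl analogue: expected lipophilicity from the cyclopropyl step

This account rests on a few compounds, and the source may have more. Where it says the series, first, only, none or still open, it means among the compounds named here.

Compound 3 `CNC(=O)c1cc(C(=O)NC2CC2)n([C@@H](C)c2ccccc2)n1` in a physicochemical assay for lipophilicity (on this read-out lower numbers stand for lower lipophilicity and higher numbers for higher lipophilicity), gives 3.6; among the three measured compounds this is the second highest number. Compound 1 `CNC(=O)c1cc(C(=O)N[C@H]2CC[C@H](O)CC2)n([C@@H](C)c2ccccc2)n1` gives 2.9 in this assay, and compound 2 `CCCNC(=O)c1cc(C(=O)NC)nn1[C@@H](C)c1ccccc1` gives 4.4. The measured steps are a number 1.50 log units higher from compound 1 to compound 2 (beyond the scatter), a number 0.70 log units higher from compound 1 to compound 3 (beyond the scatter) and a number 0.80 log units lower from compound 2 to compound 3 (beyond the scatter).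

Compound 4 `CNC(=O)c1cc(C(=O)NC)n([C@@H](C)c2ccccc2)n1` is not yet measured. It differs from compound 3 by methyl in place of cyclopropyl on an amide-type nitrogen.

Of the measured steps, the one that bears most directly on this change is a number 0.80 log units lower from compound 2 to compound 3 (beyond the scatter), where the cyclopropyl replaced a propyl of three carbons on the same amide-type nitrogen. Here the cyclopropyl of three carbons is exchanged for a methyl of one carbon. A further drop beyond the scatter is expected, somewhat smaller than that step; cyclopropyl already sits below propyl in this series. The expected step is a number 0.50 log units lower from compound 3 to compound 4 (beyond the scatter). Compound 4 is therefore estimated at 3.1 in this assay, with a range from 2.6 to 3.6.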

Compound 4, distribution coefficient: 3
For compound 4 the middle estimate is 0.10 log units above the measured one; the measured number falls inside the stated range.
By their numbers in this assay, from the lowest: compounds 1 and 4 (each within the scatter of the next); then compound 3; then compound 2.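

Against methyl on this amide-type nitrogen, this assay now gives two direct readings: a number 0.60 log units lower from compound 3 to compound 4 (beyond the scatter) for cyclopropyl and a number 1.40 log units lower from compound 2 to compound 4 (beyond the scatter) for propyl, so among these three groups methyl gives the lowest number and propyl the highest. The earlier compounds shown here placed 4-hydroxycyclohexyl lowest, but a number 0.10 log units higher from compound 1 to compound 4 (within the scatter) and so this read-out does not separate that group from methyl at this nitrogen. Nothing available gives a reason for these steps.

As far as these compounds go, whether an ethyl, a longer chain or a chain ending in an amine would fit this order remains open. So does whether cyclohexyl without the hydroxyl group would stay within the scatter of compound 1 or move towards compound 2.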